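The source may hold more compounds than are shown below. What is called first, only, known or untested is meant among the compounds shown, and "the series" means these compounds.

Going by the values given here, compound 1 `CCn1nc(-c2cccnc2)c2ccccc2c1=O` gives 1320 nM in a functional assay (trachea) with Cavia porcellus as the target (on this read-out lower numbers stand for stronger inhibition and higher numbers for weaker inhibition), the lowest of the three numbers measured so far. Compound 2 `O=c1c2ccccc2c(-c2cccnc2)nn1CCSc1ccccc1` gives 9120 nM and compound 3 `O=c1c2ccccc2c(-c2cccnc2)nn1CCSc1nccs1` gives 10500 nM. The step of a 6.9-fold higher number from compound 1 to compound 2 (0.84 log units; beyond the scatter) and the step of an 8.0-fold higher number from compound 1 to compound 3 (0.90 log units; beyond the scatter) both show that building out the chain attached to the aromatic nitrogen of compound 1 weakened inhibition, while a 1.2-fold higher number from compound 2 to compound 3 (0.06 log units; within the scatter). Compound 4 `O=C(O)Cn1nc(-c2cccnc2)c2ccccc2c1=O` has not yet been measured; it differs from compound 1 by carboxy in place of methyl on a saturated chain carbon bound to an aromatic nitrogen. Among the compounds with values here, no measured step replaces methyl by carboxy, so the two chain extensions are the only guide, and a smaller weakening is expected here. Compound 4 is therefore expected to give 4000 nM (range 1300 nM to 12000 nM), which would be an expected step of a 3.0-fold higher number from compound 1 to compound 4 (0.48 log units; beyond the scatter).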

Compound 4, half-maximal inhibitory concentration: > 100000 nM
Compound 4 gave a limit, no number; the forecaster's own chance of this, stated with the estimate: 10%; middle value at least 25-fold (1.39 log units) away from the limit.
By their numbers in this assay, from the lowest: compound 1; then compounds 2 and 3 (each within the scatter of the next). At a limit, above all of these: compound 4.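

Compound 4 gives > 100000 nM in this assay, which is a limit and not a number. The step of an at least 75-fold higher number from compound 1 to compound 4 (1.87 log units; beyond the scatter) shows that this position, on a saturated chain carbon bound to an aromatic nitrogen, can cost far more than the modest losses seen so far, so the group placed there matters and not only the building out of the chain. Carboxy also stands apart from the two sulfanyl chains, with an at least 10-fold higher number from compound 2 to compound 4 (1.04 log units; beyond the scatter) and an at least 9.5-fold higher number from compound 3 to compound 4 (0.97 log units; beyond the scatter).

As far as these compounds go, how large the true loss is stays open at a limit. Also open, from the compounds shown here alone, is whether a methyl ester, an amide, an amine or a longer chain ending in carboxy would behave like compound 4 or like compound 1.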